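Pyridin-4-yl for pyridin-3-yl: working notes on compound 3

The source may hold more compounds than are shown below. What is called first, only, known or untested is meant among the compounds shown, and "the series" means these compounds.

Measured in a functional assay on QGY-7703 cells (Homo sapiens) for cytotoxicity, read by MTT assay, with a stated time of 24 h; a lower number here means a stronger inhibitor, a higher number a weaker inhibitor:
Compound 1 `O=C1/C(=C/c2ccncc2)CNC/C1=C\c1ccccc1F`: 14200 nM
Compound 2 `O=C1/C(=C/c2cccnc2)CNC/C1=C\c1ccccc1C(F)(F)F`: 3800 nM

Compound 2 holds the lower of the two numbers in this assay, and its gap to compound 1 lies beyond the scatter. Compound 3 `O=C1/C(=C/c2ccncc2)CNC/C1=C\c1ccccc1C(F)(F)F` has not yet been measured. It differs from compound 2 as follows: pyridin-4-yl in place of pyridin-3-yl on a double-bonded chain carbon bound to a double-bonded ring carbon. This places pyridin-4-yl in place of pyridin-3-yl on a double-bonded chain carbon bound to a double-bonded ring carbon. For the measured compounds named here, no measured pair isolates this change, which leaves its size without direct evidence. Compound 1 also carries pyridin-4-yl and gives 14200 nM, but it differs from compound 3 elsewhere as well, making it only a weak guide. The expected change is small and towards a higher number, not beyond the scatter: a 1.3-fold higher number from compound 2 to compound 3 (0.12 log units; within the scatter). Compound 3 is estimated at 5000 nM, with an expected range of 1800 nM to 14000 nM.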

Compound 3, half-maximal inhibitory concentration: 4900 nM
For compound 3 the middle estimate is 1.0-fold (0.01 log units) above the measured one, within the range that was stated.
By their numbers in this assay, from the lowest: compounds 2 and 3 (each within the scatter of the next); then compound 1.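

In this assay, the exchange of pyridin-3-yl for pyridin-4-yl on a double-bonded chain carbon bound to a double-bonded ring carbon now has a direct reading: a 1.3-fold higher number from compound 2 to compound 3 (0.11 log units; within the scatter), so the two pyridine attachments are not told apart here. For the compounds shown here, compound 3 also gives the first single-place reading for trifluoromethyl in place of fluoro on an aromatic carbon, a 2.9-fold lower number from compound 1 to compound 3 (0.46 log units; beyond the scatter), which places the only difference beyond the scatter in this small set at that aromatic carbon. No supporting data bear on the cause of either step.

Open is whether a plain phenyl or a pyridin-2-yl on the same chain carbon would read like the two pyridines shown. Also open, as far as these compounds go, is whether a nitrile or methoxy on the aromatic carbon would follow the trifluoromethyl or the fluoro reading, and whether the trifluoromethyl step holds alongside pyridin-3-yl.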